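A Formyl-Methoxyphenoxy Analogue in a Cytotoxicity Series

The compounds below may be only part of what the source reports. "The series", "measured", "known", "first", "only" and "open" are said of these compounds alone.

Going by the values given here, compound 1 `COc1cc2c(cc1OC)CN(S(=O)(=O)c1ccc(-n3cc(COc4ccccc4C(C)=O)nn3)cc1)CC2` is one of three compounds measured in a functional assay on HepG2 cells (Homo sapiens) for cytotoxicity, read by MTT assay, with a stated time of 48 h; a higher number here means a weaker inhibitor, a lower number a stronger inhibitor. In this assay compound 1 gives only a limit, > 50 ug/mL. Compound 2 `Cc1ccccc1OCc1cn(-c2ccc(S(=O)(=O)N3CCc4ccccc4C3)cc2)nn1` likewise gives only a limit in this assay, > 50 ug/mL. Compound 3 `Cc1ccc(OCc2cn(-c3ccc(S(=O)(=O)N4CCc5ccccc5C4)cc3)nn2)cc1` also gives only a limit in this assay, > 50 ug/mL. Among the compounds with values here, the one measured step, a step that the two limits leave unreadable from compound 2 to compound 3, has no readable size because of the limit of > 50 ug/mL in this assay, at which 3 of the 3 values shown sit. Compound 1 therefore stands where every other value stands, at the limit, with no number to set it apart from compound 2 or compound 3.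

Compound 4 `COc1cc2c(cc1OC)CN(S(=O)(=O)c1ccc(-n3cc(COc4ccc(C=O)cc4OC)nn3)cc1)CC2` differs from compound 1 by 4-formyl-2-methoxyphenyl in place of 2-acetylphenyl on an oxygen on a saturated carbon. Within the data shown here, no measured step touches this part of the molecule in a readable way: the only step, a step that the two limits leave unreadable from compound 2 to compound 3, is unreadable, so nothing among the measured compounds points to a gain or a loss in this assay. Compound 4 is therefore expected to show a step that the limit leaves unreadable from compound 1 to compound 4, none beyond the scatter, because of the limit of > 50 ug/mL in this assay, at which 3 of the 3 values shown sit. Compound 4 is estimated at 60 ug/mL, with a range from 30 ug/mL to 150 ug/mL, and the most likely outcome is that this assay again reports only a limit for compound 4.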

Compound 4, half-maximal inhibitory concentration: > 50 ug/mL
Compound 4 was reported as a limit; the forecaster's own chance of this, stated with the estimate: 85%; the middle value is on the limit's open side.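

In this assay compound 4 gives > 50 ug/mL, which is a limit and not a number. No step can be read between compound 1 and compound 4, because both sit at the same limit: the limit of > 50 ug/mL in this assay, at which 4 of the 4 values shown sit.

The compounds shown leave open whether 4-formyl-2-methoxyphenyl and 2-acetylphenyl differ at all in this assay, since none of them gives a number.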